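The source may hold more compounds than are shown below. What is called first, only, known or untested is meant among the compounds shown, and "the series" means these compounds.

Compounds measured so far:
compound 1, `CCCCCCC(=O)Nc1ccn([C@@H]2CO[C@H](CO)O2)c(=O)n1`, 1040 nM
compound 2, `CCCCCCCCCCCC(=O)Nc1ccn([C@@H]2CO[C@H](CO)O2)c(=O)n1`, 15 nM
compound 3, `CCCCCCCCCCCCCCCCCC(=O)Nc1ccn([C@@H]2CO[C@H](CO)O2)c(=O)n1`, 25 nM

Compound 1 stands at the highest number of the three in a functional assay on A549 cells (Homo sapiens) for cytotoxicity, read by sulforhodamine B assay, with a stated time of 72 h; a lower number here means a stronger inhibitor, a higher number a weaker inhibitor. The nearest measured compound is compound 3, reached by a 42-fold lower number from compound 1 to compound 3 (1.62 log units; beyond the scatter), and the furthest is compound 2, reached by a 69-fold lower number from compound 1 to compound 2 (1.84 log units; beyond the scatter). The two longer-chain compounds lie close together, the step of a 1.7-fold higher number from compound 2 to compound 3 (0.22 log units; within the scatter) being within the scatter.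

Compound 4, `O=C(Nc1ccn([C@@H]2CO[C@H](CO)O2)c(=O)n1)C1CCCCC1`, differs from compound 1 by cyclohexyl in place of hexyl on a carbonyl carbon. For the measured compounds named here, none of the measured steps alters the group on the carbonyl carbon in this way: the steps of a 69-fold lower number from compound 1 to compound 2 (1.84 log units; beyond the scatter) and a 42-fold lower number from compound 1 to compound 3 (1.62 log units; beyond the scatter) both lengthen the chain and give large gains, but they say nothing about closing a chain of the same size into a ring. Going by the values given here, with no direct precedent, the expected step from compound 1 to compound 4 in this assay is a 1.4-fold higher number from compound 1 to compound 4 (0.16 log units; within the scatter), that is, no change clearly beyond the scatter. Compound 4 is therefore expected to give about 1500 nM, within a range from 400 nM to 6000 nM.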

Compound 4, half-maximal inhibitory concentration: 7370 nM
Estimate against measurement, compound 4: 4.9-fold (0.69 log units) below; measured number outside the range, above it.
By their numbers in this assay, from the lowest: compounds 2 and 3 (each within the scatter of the next); then compound 1; then compound 4.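

In this assay, the group on the carbonyl carbon responds to its shape as well as its length: with the carbon count unchanged, cyclohexyl in place of hexyl gives a 7.1-fold higher number from compound 1 to compound 4 (0.85 log units; beyond the scatter). Among the steps shown, this is the only one to raise the number beyond the scatter, and it does so without adding a single heavy atom, whereas the earlier large steps all lengthened an open chain. No evidence is available to explain this difference between the ring and the open chain.

Going by these compounds, it remains open how a phenyl group or a branched group such as tert-butyl on the same carbonyl carbon would compare with hexyl and cyclohexyl. Also open, on these data alone, is whether a longer chain carrying a cyclohexyl group or an amine would keep the low numbers of the long-chain compounds.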